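Chain shortening on the weaker core: compound 2 to compound 4

This account rests on a few compounds, and the source may have more. Where it says the series, first, only, none or still open, it means among the compounds named here.

Compound 2 `ClCCCc1cc[nH]n1` gives 40000 nM in an assay for inhibition of alcohol dehydrogenase (Equus caballus), read by spectrophotometry, in the presence of a further agent that is not named here (a higher number here means weaker binding, a lower number tighter binding), the highest of the three numbers. Compound 1 `ClCCCc1cn[nH]c1` gives 20 nM and compound 3 `ClCc1cn[nH]c1` gives 2700 nM. Compound 4 `OCCc1cc[nH]n1` differs from compound 2 by hydroxy in place of chloromethyl on a saturated chain carbon, two bonds along the chain from an aromatic carbon. Within the data shown here, no measured step exchanges chlorine for a hydroxyl; the only step that bears on it, shortening the chain on the other core, reads a 140-fold higher number from compound 1 to compound 3 (2.13 log units; beyond the scatter), beyond the scatter and towards weaker binding. A move of similar direction is therefore expected here, though compound 2 already stands so high that the assay may report only a limit. Compound 4 is estimated at 150000 nM (range 30000 nM to 800000 nM), an expected step of a 3.8-fold higher number from compound 2 to compound 4 (0.57 log units; beyond the scatter).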

Compound 4, dissociation constant: 170000 nM
Estimate against measurement, compound 4: 1.1-fold (0.05 log units) below, and the stated range covers the measured number.
By their numbers in this assay, from the lowest: compound 1; then compound 3; then compound 2; then compound 4.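

In this assay the exchange reads a 4.3-fold higher number from compound 2 to compound 4 (0.63 log units; beyond the scatter), so chlorine-bearing chain is not needed for a measurable number on this core, and replacing it with hydroxy still shifts binding weaker even though compound 2 already stands high. The direction matches the chain shortening on the other core, but that step changes a different group, so the two cannot be read as one rule. Nothing available accounts for the shift. On these data alone, whether hydroxy has a similar effect on the core of compound 1 remains open. So does the outcome of placing an amine or a carboxylic acid at this chain end.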